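Swapping a Halophenyl for a Halobenzyl Group

The source may report more compounds than this note shows. Statements on the series, on what has been measured and on what is new or still open speak of the compounds shown alone.

Three compounds have been measured in an assay on CHO cells for displacement of a labelled ligand from adenosine receptor A2b (Homo sapiens), read by scintillation counting, with a stated time of 75 min, in the presence of a further agent that is not named here; on this read-out lower numbers stand for stronger inhibition and higher numbers for weaker inhibition:

compound 1 `CCCn1c(=O)[nH]c2nc(-c3ccc(S(=O)(=O)N4CCN(Cc5ccc(Br)cc5)CC4)cc3)[nH]c2c1=O`: 0.153 nM
compound 2 `CCCn1c(=O)[nH]c2nc(-c3ccc(S(=O)(=O)N4CCN(c5cccc(F)c5)CC4)cc3)[nH]c2c1=O`: 0.632 nM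
compound 3 `CCCn1c(=O)[nH]c2nc(-c3ccc(S(=O)(=O)N4CCN(c5cccc(Cl)c5)CC4)cc3)[nH]c2c1=O`: 0.342 nM

Compound 3 gives the second highest of the three numbers. Its nearest neighbour is compound 2, and that difference, a 1.8-fold lower number from compound 2 to compound 3 (0.27 log units; within the scatter), lies within the scatter, so no order between the two can be claimed. The step of a 2.2-fold higher number from compound 1 to compound 3 (0.35 log units; beyond the scatter) lies beyond the scatter, so compound 1 stands stronger than compound 3.

Compound 4 `CCCn1c(=O)[nH]c2nc(-c3ccc(S(=O)(=O)N4CCN(Cc5ccc(Br)c(F)c5)CC4)cc3)[nH]c2c1=O` has not yet been measured. It differs from compound 3 by 4-bromo-3-fluorobenzyl in place of 3-chlorophenyl on an amine nitrogen in a ring. Among the measured compounds shown here, two measured steps bear on this change. Compound 1 carries 4-bromobenzyl at the same place, and a 2.2-fold higher number from compound 1 to compound 3 (0.35 log units; beyond the scatter) shows that exchanging it for 3-chlorophenyl raised the number modestly; compound 4 reverses that exchange while adding a fluorine to the benzyl ring. The comparison a 1.8-fold lower number from compound 2 to compound 3 (0.27 log units; within the scatter) shows that chloro against fluoro on an aromatic carbon made no difference beyond the scatter, so the extra fluorine is not expected to shift the number much. Compound 4 is therefore expected to land close to compound 1, with an estimated step of a 1.9-fold lower number from compound 3 to compound 4 (0.28 log units; within the scatter) in this assay. The estimate for compound 4 is 0.18 nM, within a range from 0.07 nM to 0.5 nM.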

Compound 4, inhibition constant: 0.473 nM
Compound 4: the middle estimate sits 2.6-fold (0.42 log units) below what was measured, and the stated range covers the measured number.
By their numbers in this assay, from the lowest: compound 1; then compounds 3, 4 and 2 (each within the scatter of the next).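

In this assay the group on the ring nitrogen proves sensitive to one small edit on its benzyl ring: fluoro in place of hydrogen on an aromatic carbon gives a 3.1-fold higher number from compound 1 to compound 4 (0.49 log units; beyond the scatter) and removes the edge that the 4-bromobenzyl group held over both halophenyl groups. The 4-bromo-3-fluorobenzyl group cannot be told apart from either halophenyl group, with a 1.4-fold higher number from compound 3 to compound 4 (0.14 log units; within the scatter) and a 1.3-fold lower number from compound 2 to compound 4 (0.13 log units; within the scatter) both lying within the scatter, so a benzyl group at this place does not by itself secure the low number seen for compound 1. Nothing available here accounts for the effect of the added fluorine.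

Still open, from the compounds shown here alone, is whether this shift is particular to fluorine or would also appear with a methyl or methoxy group on the same ring carbon. These compounds also leave unsettled how a plain benzyl group without any halogen, or a benzyl ring carrying chlorine in place of the bromine, would compare with the 4-bromobenzyl group of compound 1.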